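The source may hold more compounds than are shown below. What is called first, only, known or untested is meant among the compounds shown, and "the series" means these compounds.

Compound 3 `Cc1cccc(C(=O)c2ccn(-c3ccc4c(c3)B(O)OC4)c2)c1` was tested in an ADME assay on L929 cells (Mus musculus) for cytotoxicity, read by resazurin assay, with a stated time of 72 h (a higher number here means a weaker inhibitor, a lower number a stronger inhibitor), where compound 3 reaches only the assay's limit of > 10 ug/mL. Its neighbours stand the same way: compound 1 `OB1OCc2ccc(-n3cccc3Sc3ccccc3Cl)cc21` gives the limit > 10 ug/mL in this assay. Compound 2 `OB1OCc2ccc(-n3cccc3Sc3ccc(Cl)c(Cl)c3)cc21` likewise gives the limit > 10 ug/mL. For the measured compounds named here, the only one-place step among them, a step that the two limits leave unreadable from compound 1 to compound 2, cannot be read, since (the limit of > 10 ug/mL in this assay, at which 3 of the 3 values shown sit).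

Compound 4 `CCCC(=O)c1ccn(-c2ccc3c(c2)B(O)OC3)c1` differs from compound 3 by propyl in place of 3-methylphenyl on a carbonyl carbon. Going by the values given here, no measured step bears on a change at a carbonyl carbon, and every value here is a limit rather than a number. The expected step in this assay is therefore a step that the limit leaves unreadable from compound 3 to compound 4, nothing beyond the scatter. Compound 4 is estimated at 15 ug/mL, within 10 ug/mL to 40 ug/mL, most likely again reported only as a limit.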

Compound 4, half-maximal inhibitory concentration: > 10 ug/mL
Compound 4 gave a limit, no number; the forecaster's own chance of this, stated with the estimate: 85%; the middle value lies beyond the limit too.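

The step from compound 3 to compound 4 cannot be read, since both values are limits and not numbers: the limit of > 10 ug/mL in this assay, at which 4 of the 4 values shown sit. The compounds shown leave open whether the result in this assay changes at all with propyl in place of 3-methylphenyl on a carbonyl carbon.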